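Benzylation of the sulfonamide nitrogen in a biphenyltetrazole series

This account rests on a few compounds, and the source may have more. Where it says the series, first, only, none or still open, it means among the compounds named here.

Compound 1 `CCCCc1ccc(CNCc2ccccc2)c(=O)n1Cc1ccc(-c2ccccc2-c2nn[nH]n2)cc1`: 1 nM
Compound 2 `CCCCc1ccc(CNS(C)(=O)=O)c(=O)n1Cc1ccc(-c2ccccc2-c2nn[nH]n2)cc1`: 2 nM

In a functional assay (aorta) for antagonist activity, with Oryctolagus cuniculus as the target (on this read-out lower numbers stand for stronger inhibition and higher numbers for weaker inhibition), compound 1 gives 1 nM and compound 2 gives 2 nM; the step of a 2.0-fold higher number from compound 1 to compound 2 (0.30 log units; within the scatter) is within the scatter, so the two numbers are not distinguished. Among the compounds with values here, compound 2 stands at the higher of the two numbers, with compound 1 as its only neighbour.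

Compound 3 `CCCCc1ccc(CN(Cc2ccccc2)S(C)(=O)=O)c(=O)n1Cc1ccc(-c2ccccc2-c2nn[nH]n2)cc1` has not been measured. The change from compound 2 is benzyl in place of hydrogen on a sulfonamide nitrogen. Compound 1 carries a benzyl on an amine nitrogen and compound 2 carries a methylsulfonyl there; both give low numbers, and the step of a 2.0-fold higher number from compound 1 to compound 2 (0.30 log units; within the scatter) between them is within the scatter. Compound 3 carries both groups on the one nitrogen. On this basis compound 3 is expected to stay in the same low range, with a step of no change at the digits printed from compound 2 to compound 3 (within the scatter) that is not expected to exceed the scatter. The estimate for compound 3 in this assay is 2 nM, within 0.5 nM to 8 nM.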

Compound 3, half-maximal inhibitory concentration: 2 nM
Compound 3: middle estimate and measured number agree at the digits printed; low and high end bracket the measured number.
By their numbers in this assay, from the lowest: compounds 1, 2 and 3 (each within the scatter of the next).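

Compound 3 shows that, in this assay, this sulfonamide nitrogen need not keep its hydrogen: benzyl in its place gives no change at the digits printed from compound 2 to compound 3 (within the scatter). Read from the amine side, methylsulfonyl in place of hydrogen on the nitrogen gives a 2.0-fold higher number from compound 1 to compound 3 (0.30 log units; within the scatter), so the two groups seen singly in compound 1 and compound 2 can stand together on one nitrogen without the numbers being distinguished. Nothing available explains this result.

Going by these compounds, whether a carboxylic acid-bearing chain or a longer alkyl chain in place of benzyl on this nitrogen, or a phenylsulfonyl in place of methylsulfonyl, would stay in the same range remains open. All three compounds share the same core, so these numbers speak only to this one nitrogen.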